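The source may report more compounds than this note shows. Statements on the series, on what has been measured and on what is new or still open speak of the compounds shown alone.

Measured so far in an ADME assay on microsomes from liver (Homo sapiens) for metabolic stability, tested at 2.5 uM; on this read-out higher numbers stand for fast clearance and lower numbers for slow clearance:
compound 1 `COc1ccc(-c2c(S(=O)(=O)c3ccc(F)cc3)cnc3cc(F)ccc23)cc1` gives 1.77 mL/min.
compound 2 `COc1ccc(-c2c(S(=O)(=O)c3cc(Cl)cc(Cl)c3)cnc3cc(F)ccc23)cc1` gives 1 mL/min.

Among the compounds with values here, compound 2 stands at the lowest of these two numbers; its nearest neighbour is compound 1, and the single step between them, a 1.8-fold lower number from compound 1 to compound 2 (0.25 log units; within the scatter), lies within the scatter. Compound 3 `COc1ccc(-c2c(S(=O)(=O)c3ccc(F)c(Cl)c3)cnc3cc(F)ccc23)cc1` differs from compound 2 by one change on a sulfonyl sulfur: 3-chloro-4-fluorophenyl in place of 3,5-dichlorophenyl on a sulfonyl sulfur. Within the data shown here, the only measured step that bears on this is a 1.8-fold lower number from compound 1 to compound 2 (0.25 log units; within the scatter), where one phenyl ring on the same sulfonyl sulfur was exchanged for another and the number moved within the scatter. The ring entering compound 3 carries both chlorine and fluorine, whereas the two measured compounds carry chlorine alone or fluorine alone, so a number close to both measured ones is expected, with no step beyond the scatter in this assay, a 1.3-fold higher number from compound 2 to compound 3 (0.11 log units; within the scatter). For compound 3 the estimate is 1.3 mL/min, within a range from 0.6 mL/min to 2.8 mL/min.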

Compound 3, intrinsic clearance in a liver preparation (reported as CLH), per the amount of preparation that the assay uses: 1.08 mL/min
Estimate against measurement, compound 3: 1.2-fold (0.08 log units) above; the range from low to high includes it.
By their numbers in this assay, from the lowest: compounds 2, 3 and 1 (each within the scatter of the next).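

In this assay, 3-chloro-4-fluorophenyl in place of 3,5-dichlorophenyl on the sulfonyl sulfur gives a 1.1-fold higher number from compound 2 to compound 3 (0.03 log units; within the scatter), and chloro in place of hydrogen on an aromatic carbon gives a 1.6-fold lower number from compound 1 to compound 3 (0.21 log units; within the scatter). Within the data shown here, the second step is the first here to isolate a single added chlorine, and it stays within the scatter, so all three phenyl rings, carrying fluorine, chlorine or both, now read alike at this position. Nothing available here explains why these rings give such similar numbers.

All three rings carry only halogens, so the compounds shown leave open how the clearance number would respond to a different kind of group at this sulfur. A phenyl ring bearing an amine or a carboxylic acid, or an alkyl chain in place of the ring, could stay within the scatter or move well beyond it.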